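Phenylsulfonyl for carboxyhexyl on a vitamin D receptor ligand

The source may report more compounds than this note shows. Statements on the series, on what has been measured and on what is new or still open speak of the compounds shown alone.

Measured so far:
compound 1, `CCC(CC)(c1ccc(OCCCCCO)c(C)c1)c1ccc(OCC(O)C(C)(C)C)c(OCC(O)C(C)(C)C)c1`: 67%
compound 2, `CCC(CC)(c1ccc(OCCCCCCC(=O)O)c(C)c1)c1ccc(OCC(O)C(C)(C)C)c(OCC(O)C(C)(C)C)c1`: "not active" (no number reported)

Two compounds share a core and differ only in the chain carried on one aromatic oxygen. In an assay on cells for binding affinity to vitamin D3 receptor (Homo sapiens), read by fluorescence, tested at 1 uM (a lower number here means less inhibition, a higher number more inhibition at the concentration tested (going by the name of the read-out)), compound 1 gives 67%. In the same assay compound 2 is recorded only as "not active" (no number reported), with no number behind it, so compound 2 cannot be placed on a scale; all that is known of compound 2 is that verdict, reported as not active.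

Compound 3, `CCC(CC)(c1ccc(OS(=O)(=O)c2ccccc2)c(C)c1)c1ccc(OCC(O)C(C)(C)C)c(OCC(O)C(C)(C)C)c1`, has not yet been measured. It differs from compound 2 in one place: phenylsulfonyl in place of 6-carboxyhexyl on an oxygen on an aromatic ring. With no number for compound 2, the size of the step from compound 2 to compound 3 in this assay cannot be stated; what can be said is that any measurable inhibition for compound 3 would be a move away from the verdict reported for compound 2, and the two compounds are not expected to fall within the usual scatter of each other.

Compound 3 is estimated at 40%, in a range from 5% to 75%.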

Compound 3, a percentage reported as inhibition, at one concentration (the size of the read-out at that concentration, not a potency): "not active" (no number reported)
The entry for compound 3 holds no number, and the estimate cannot be compared.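

In this assay, within the data shown here, compound 2 is recorded as "not active" (no number reported) and compound 3 as "not active" (no number reported), so no step from one to the other can be read. No evidence shown bears on this result. The compounds shown leave open whether 6-carboxyhexyl and phenylsulfonyl differ at all in this assay.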